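Compound 3 and the exchange at its carbonyl carbon

This account rests on a few compounds, and the source may have more. Where it says the series, first, only, none or still open, it means among the compounds named here.

In a functional assay on A2780 cells (Homo sapiens) for inhibition, read by sulforhodamine B assay, with a stated time of 72 h (on this read-out lower numbers stand for stronger inhibition and higher numbers for weaker inhibition), compound 3 `O=C(NCc1ccc(S(=O)(=O)N2CCCCC2)cc1)c1cc2cnccc2o1` gives 1500 nM, and compound 2 `O=C(NCc1ccc(S(=O)(=O)N2CCCCC2)cc1)c1cc2cnccc2s1` gives 1600 nM. These two numbers sit within the scatter of each other. Compound 1 `Cc1ccccc1S(=O)(=O)c1ccc(CNC(=O)c2cc3cnccc3[nH]2)cc1` stands far lower, at 13 nM, a gap beyond the scatter from compound 3. Compound 4 `O=C(NCc1ccc(S(=O)(=O)N2CCCCC2)cc1)c1cc2ccncc2[nH]1` has not yet been measured. It differs from compound 3 in one place, on a carbonyl carbon whose other neighbour is an amide-type nitrogen: a group of 9 heavy atoms (7 carbon, 2 nitrogen; one five-membered aromatic ring with 1 hetero atom, one six-membered aromatic ring with 1 hetero atom) in place of a group of 9 heavy atoms (7 carbon, 1 nitrogen, 1 oxygen; one five-membered aromatic ring with 1 hetero atom, one six-membered aromatic ring with 1 hetero atom), on a carbonyl carbon.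

Within the data shown here, the only measured exchange at this place is a 1.1-fold lower number from compound 2 to compound 3 (0.03 log units; within the scatter), which lies within the scatter. Compound 1 differs from compound 3 in more than one place, so its low number cannot be assigned to this group alone. It still leaves open some move toward lower numbers. A modest step is therefore expected, with wide uncertainty: the estimate is a 1.9-fold lower number from compound 3 to compound 4 (0.27 log units; within the scatter).

For compound 4 the expected value is 800 nM, with an estimated range from 150 nM to 4000 nM.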

Compound 4, half-maximal inhibitory concentration: 1700 nM
Compound 4: the middle estimate sits 2.1-fold (0.33 log units) below what was measured; the range from low to high includes it.
By their numbers in this assay, from the lowest: compound 1; then compounds 3, 2 and 4 (each within the scatter of the next).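

In this assay the exchange gives a 1.1-fold higher number from compound 3 to compound 4 (0.05 log units; within the scatter) and also a 1.1-fold higher number from compound 2 to compound 4 (0.03 log units; within the scatter) and both steps lie within the scatter. Where the earlier compounds showed one exchange at this carbonyl carbon without a readable shift, three groups now read alike, and that holds even though the entering group has 1 hydrogen-bond donor and the leaving group has 0. Nothing available explains why these numbers stay together.

The low number of compound 1 remains unassigned: it differs from compound 3 and compound 4 in more than one place, so its group cannot be judged alone. The compounds shown also leave open how a plain phenyl ring, or an amine on the fused group, would read at this carbonyl carbon.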